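A few compounds are considered here, and "the series" means these few. Any claim that something is new, unique, unknown or untested is made for them only; others in the source may bear on it.

Compound 1 `CN1CCC(c2c[nH]c3ccc(NC(=O)C4CC4)nc23)CC1` stands second highest of the three numbers in an assay for binding affinity to 5-hydroxytryptamine receptor 1F (Homo sapiens), read by radioligand binding (on this read-out higher numbers stand for weaker inhibition and lower numbers for stronger inhibition), where compound 1 gives 9.8 nM. Compound 2 `COc1ccccc1C(=O)Nc1ccc2[nH]cc(C3CCN(C)CC3)c2n1` gives 20 nM and compound 3 `CN1CCC(c2c[nH]c3ccc(NC(=O)c4ccc(C#N)cc4)nc23)CC1` gives 7.2 nM. Compound 4 `CN1CCC(c2c[nH]c3ccc(NC(=O)c4cccs4)nc23)CC1` differs from compound 1 by thiophen-2-yl in place of cyclopropyl on a carbonyl carbon. The two measured steps from the same cyclopropyl starting point bear on this: a 2.0-fold higher number from compound 1 to compound 2 (0.31 log units; beyond the scatter), and a 1.4-fold lower number from compound 1 to compound 3 (0.13 log units; within the scatter). Both swaps of cyclopropyl for an aromatic ring on the carbonyl carbon moved this assay only modestly, in opposite directions, so for the thiophen-2-yl ring no step beyond the scatter is expected in either direction. The estimate for compound 4 is therefore 9 nM, with a range of 3.5 nM to 25 nM, meaning an expected step of a 1.1-fold lower number from compound 1 to compound 4 (0.04 log units; within the scatter).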

Compound 4, inhibition constant: 7.1 nM
The estimate for compound 4 lay 1.3-fold (0.10 log units) above the measured number; the range from low to high includes it.
By their numbers in this assay, from the lowest: compounds 4, 3 and 1 (each within the scatter of the next); then compound 2.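

In this assay, thiophen-2-yl on the carbonyl carbon is level with cyclopropyl (a 1.4-fold lower number from compound 1 to compound 4 (0.14 log units; within the scatter)) and with 4-cyanophenyl (a 1.0-fold lower number from compound 3 to compound 4 (0.01 log units; within the scatter)), so three differing rings at this position now lie within the scatter of one another. Only 2-methoxyphenyl stands apart (a 2.8-fold lower number from compound 2 to compound 4 (0.45 log units; beyond the scatter)). The data shown offer no explanation for these steps.

Still open, on these data alone, is whether an unsubstituted phenyl ring would sit with this group or with 2-methoxyphenyl. Also open, as far as these compounds go, is how an amine, a carboxylic acid or a longer alkyl chain would read at this position.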